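Opening a Ring: From Cyclohexyl Diamine to Hexyl Chain

The source may hold more compounds than are shown below. What is called first, only, known or untested is meant among the compounds shown, and "the series" means these compounds.

Measured compounds:
- compound 1 `N[C@H]1CC[C@H](Nc2c(C(=O)NCc3ccc(F)cc3)nc(Br)c3cccnc23)CC1`: 7000 nM
- compound 2 `COC(=O)c1nc(Br)c2cccnc2c1N[C@H]1CC[C@H](N)CC1`: "not determined" (no result reported)

The series is followed in a functional assay on HCT-116 cells (Homo sapiens) for cytotoxicity, read by MTT assay, with a stated time of 72 h; on this read-out higher numbers stand for weaker inhibition and lower numbers for stronger inhibition. Compound 1 gives 7000 nM, and because compound 2 gives "not determined" (no result reported), compound 1 stands alone as the only numbered point. Compound 3 `NCCCCCCNc1c(C(=O)NCc2ccc(F)cc2)nc(Br)c2cccnc12` carries the same core, the same amide and the same bromine, but differs in one place: 6-aminohexyl in place of 4-aminocyclohexyl on a nitrogen on an aromatic ring. The ring of the 4-aminocyclohexyl group is thus opened into a 6-aminohexyl chain of the same atom count, keeping one donor and one acceptor and the terminal amine. Within the data shown here, no step between measured compounds is available to calibrate this change, so the expectation rests on compound 1 alone. For compound 3 the step of a 1.4-fold higher number from compound 1 to compound 3 (0.15 log units; within the scatter) is expected to be small, at most a modest loss that may not exceed the scatter. Compound 3 is estimated at 10000 nM, within 3000 nM to 35000 nM.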

Compound 3, half-maximal inhibitory concentration: 7000 nM
Compound 3: middle estimate off by 1.4-fold (0.15 log units), on the high side; the range from low to high includes it.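

In this assay, among these compounds, putting 6-aminohexyl in place of 4-aminocyclohexyl on a nitrogen on an aromatic ring gives no change at the digits printed from compound 1 to compound 3 (within the scatter), the first step that can be read at this position. In this one pair, the six-membered ring of carbon is therefore not required to hold the number where it stands, and an open chain with the same terminal amine reads the same. No measured evidence accompanies this result to say why the two groups read alike.

The compounds shown leave open whether a shorter or a longer chain ending in an amine would read the same as the 6-aminohexyl chain. They also leave open whether the terminal amine itself matters, which a hexyl chain ending in a hydroxyl group or a carboxylic acid could test.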